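The source may report more compounds than this note shows. Statements on the series, on what has been measured and on what is new or still open speak of the compounds shown alone.

Three compounds have been measured in a functional assay on the whole organism with Rattus norvegicus as the target, at a dose of 40 mg/kg by the intraperitoneal route; a lower number here means less inhibition, a higher number more inhibition at the dose given (going by the name of the read-out):

Compound 1, `Cc1cc(OCc2ccccc2)c2nc(C)c(C)n2c1`, gives 86%.
Compound 2, `Cc1ccn2c(C)c(C)nc2c1OCc1ccccc1`, gives 92%.
Compound 3, `CCc1nc2c(OCc3ccccc3)cccn2c1N`, gives 83%.

The three numbers sit close together. For compound 3, the gap to compound 1 and the gap to compound 2 both fall within the usual scatter of repeated measurements, so on these numbers alone the three compounds cannot be told apart in this assay. Among the compounds with values here, no pair among them differs in only one place, so no step from one measured compound to another can be read off here.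

Compound 4, `CC(C)(C)c1nc2c(OCc3ccccc3)cccn2c1N`, has not yet been measured. It differs from compound 3 in a single place: tert-butyl in place of ethyl on an aromatic carbon. The rest of the molecule, including the shared core and the amino group it carries, is unchanged.

Within the data shown here, no measured pair shows what such a change does in this assay; there is no basis here for expecting a shift beyond the scatter in either direction. Compound 4 is therefore expected to give about 80%, within a range of 60% to 95%. The estimated step of a number 3 percentage points lower from compound 3 to compound 4 (within the scatter) is expected to stay within the scatter, so compound 4 is expected to land close to compound 3.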

Compound 4, a percentage reported as inhibition, in the whole organism at one dose (the size of the read-out at that dose, not a potency): 0%
Beside the measured number, compound 4's estimate is 80 percentage points above it, and the stated range ends above it.
By their numbers in this assay, from the lowest: compound 4; then compounds 3, 1 and 2 (each within the scatter of the next).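

In this assay, replacing ethyl with tert-butyl on an aromatic carbon next to the ring atom that bears an amino group gives a number 83 percentage points lower from compound 3 to compound 4 (beyond the scatter), with the rest of the molecule unchanged. The earlier compounds shown here all sat within the scatter of one another and no pair differed in only one place, so they could not show that any single place mattered; this pair shows that this position is far from indifferent, and that one change of group here can decide whether inhibition is seen at this dose. As this is a single-dose read-out, the step describes the size of the effect at that dose rather than a change in potency, and nothing available explains why the change has such a large effect.

The compounds shown leave open whether an isopropyl group or a longer chain such as propyl at this place would stay close to compound 3 or fall towards compound 4. Compound 4 is also the only compound shown with tert-butyl, so whether the same result would hold with a methyl group or a hydrogen in place of the amino group remains unknown.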